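From methoxy to nitro on an aromatic carbon

This account rests on a few compounds, and the source may have more. Where it says the series, first, only, none or still open, it means among the compounds named here.

In a functional assay on MCF7 cells (Homo sapiens) for inhibition, read by MTT assay, with a stated time of 48 h, tested at 10 uM (a higher number here means more inhibition of growth at the concentration tested, a lower number less inhibition of growth), compound 2 `C#CCOc1ccc(/C=C/C(=O)c2ccc(OC)cc2)cc1` gives 32%, the lower of the two numbers, while compound 1 `C#CCOc1ccc(/C=C/C(=O)c2ccc(Br)cc2)cc1` gives 45%. Compound 3 `C#CCOc1ccc(/C=C/C(=O)c2ccc([N+](=O)[O-])cc2)cc1` carries nitro in place of methoxy on an aromatic carbon. Among the compounds with values here, only one measured step bears on this place, a number 13 percentage points lower from compound 1 to compound 2 (beyond the scatter), with methoxy in place of bromo. Within the data shown here, no nitro compound has been measured, so that step suggests a size more firmly than a direction. A modest rise is expected with methoxy leaving. The expected change is a number 10 percentage points higher from compound 2 to compound 3 (within the scatter). Compound 3 is estimated at 42%, within an expected range of 28% to 58%.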

Compound 3, percent growth inhibition at one concentration: 44%
Estimate against measurement, compound 3: 2 percentage points below; the range from low to high includes it.
By their numbers in this assay, from the lowest: compound 2; then compounds 3 and 1 (each within the scatter of the next).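

Nitro in place of methoxy on this aromatic carbon gives a real step in this assay, with a number 12 percentage points higher from compound 2 to compound 3 (beyond the scatter), while nitro in place of bromo gives a number 1 percentage points lower from compound 1 to compound 3 (within the scatter) and so cannot be told apart from bromo. Of the three groups at this place, methoxy alone now stands apart, with the lowest number. Nothing measured here explains this. From the compounds shown here alone, whether an amine or a carboxylic acid at this place would match nitro and bromo or fall nearer methoxy stays open.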